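The compounds below may be only part of what the source reports. "The series", "measured", "known", "first", "only" and "open" are said of these compounds alone.

Three compounds share one core and differ only in the group attached on an aromatic carbon of the five-membered ring. Compound 1 `Cc1cc(NC(=O)Cn2nnc(-c3cc(Cl)cc(Cl)c3)n2)n(C2CCCCC2)n1` gives 980 nM in an assay on HEK293 cells for activation of Kir3.1/Kir3.2 (Homo sapiens), read by thallium flux; on this read-out higher numbers stand for an effect only at larger amounts of compound and lower numbers for an effect already at smaller amounts. Compound 2 `Cc1cc(NC(=O)Cn2nnc(-c3ccccc3F)n2)n(C2CCCCC2)n1` gives 187 nM in this assay, and compound 3 `Cc1cccc(-c2nnn(CC(=O)Nc3cc(C)nn3C3CCCCC3)n2)c1` gives 129 nM in this assay. Compound 3 therefore has the lowest of the three numbers, though its gap to compound 2 is small: a 1.4-fold lower number from compound 2 to compound 3 (0.16 log units; within the scatter). The larger steps are a 5.2-fold lower number from compound 1 to compound 2 (0.72 log units; beyond the scatter) and a 7.6-fold lower number from compound 1 to compound 3 (0.88 log units; beyond the scatter).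

Compound 4 `Cc1cc(NC(=O)Cn2nnc(C3CC3)n2)n(C2CCCCC2)n1` is not yet measured. It differs from compound 3 in one place: cyclopropyl in place of 3-methylphenyl on an aromatic carbon. Among the measured compounds shown here, none of the measured steps bears on this change directly, since every measured step exchanges one six-membered aromatic ring for another, while here the aromatic ring leaves altogether and a three-membered non-aromatic ring enters. For the measured compounds named here, the data thus give no anchor for the size of this step, only the observation that the aromatic group has been present in every compound measured so far. Compound 4 is expected to lie at 900 nM in this assay, within a wide range from 200 nM to 4000 nM. The estimated step of a 7.0-fold higher number from compound 3 to compound 4 (0.84 log units; beyond the scatter) is an expectation of a higher number, held with low confidence.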

Compound 4, half-maximal effective concentration: > 3000 nM
Compound 4 was reported as a limit; the forecaster's own chance of this, stated with the estimate: 15%; middle value at least 3.3-fold (0.52 log units) from the limit.
By their numbers in this assay, from the lowest: compounds 3 and 2 (each within the scatter of the next); then compound 1. At a limit, above all of these: compound 4.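

Compound 4 is reported only as a limit, not as a number: the limit of > 3000 nM in this assay, at which 1 of the 4 values shown sits.

Among the earlier compounds, exchanging one aromatic group for another on this carbon left every value under that limit, but cyclopropyl in place of the aromatic ring gives an at least 23-fold higher number from compound 3 to compound 4 (1.36 log units; beyond the scatter) and an at least 16-fold higher number from compound 2 to compound 4 (1.20 log units; beyond the scatter), the largest steps in the series. Even against the 3,5-dichlorophenyl group, which has the highest number of the three aromatic compounds, the change gives an at least 3.0-fold higher number from compound 1 to compound 4 (0.48 log units; beyond the scatter), so at this position on the ring with 4 nitrogen, cyclopropyl does not stand in for any of the aromatic groups shown.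

The loss of the aromatic ring and the drop from 7 heavy atoms to 3 come together in this change, and the compounds shown do not separate them. From the compounds shown here alone, how a cyclohexyl or a pyridyl group would fare at this position remains open, as does where compound 4 would lie if given a number.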